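A few compounds are considered here, and "the series" means these few. Any claim that something is new, unique, unknown or untested is made for them only; others in the source may bear on it.

In a functional assay on MCF7 cells (Homo sapiens) for inhibition, read by MTT assay, with a stated time of 72 h (a lower number here means a stronger inhibitor, a higher number a weaker inhibitor), compound 1 `Nc1ncnc2c1c(-c1cnc3[nH]ccc3c1)nn2CC(=O)NO` gives > 150000 nM, which is a limit and not a number. Compound 3 `Nc1ncnc2c1c(-c1cnc3[nH]ccc3c1)nn2CCCCC(=O)NO` gives > 150000 nM, again only a limit, and so it stands at the limit of > 150000 nM in this assay, at which 2 of the 3 values shown sit. Compound 2 `Nc1ncnc2c1c(-c1cnc3[nH]ccc3c1)nn2CCCCCCCCC(=O)NO` gives a true reading of 24700 nM.

Compound 4 `Nc1ncnc2c1c(-c1cnc3[nH]ccc3c1)nn2CCCCCC(=O)NO` differs from compound 3 by one change: (hydroxycarbamoyl)methyl in place of hydroxycarbamoyl on a saturated chain carbon, four bonds along the chain from an aromatic nitrogen.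

Within the data shown here, two measured steps bear on this change. Among the measured compounds shown here, the first is a step that the two limits leave unreadable from compound 1 to compound 3, so it gives no size to work from. The second is an at least 6.0-fold higher number from compound 2 to compound 3 (0.78 log units; beyond the scatter), and the chain of compound 4 lies along the way of that step. A lower number is therefore expected, but only a modest part of that step, and the reading may well remain at the limit. The estimate amounts to an at least 1.6-fold lower number from compound 3 to compound 4 (0.22 log units; that floor lies within the scatter), an expected step whose size is uncertain. For compound 4 the expected value is 90000 nM, with an estimated range from 35000 nM to 200000 nM.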

Compound 4, half-maximal inhibitory concentration: > 150000 nM
Compound 4: no number, only a limit (the forecaster's own chance of this, stated with the estimate: 45%); middle value at least 1.6-fold (0.22 log units) away from the limit.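

Compound 4 gives > 150000 nM in this assay, which is a limit and not a number. Its steps to compound 1 and compound 3 cannot be read, so (hydroxycarbamoyl)methyl in place of hydroxycarbamoyl has no measurable size here, and this change does not bring the reading off the limit. The one readable comparison is an at least 6.0-fold higher number from compound 2 to compound 4 (0.78 log units; beyond the scatter), which places the chain of compound 4 with the shorter chains and leaves compound 2 as the only true reading: the limit of > 150000 nM in this assay, at which 3 of the 4 values shown sit.

The compounds shown leave open at which chain length, between those of compound 4 and compound 2, a true reading first appears, and whether a longer chain than that of compound 2 gives a lower number. They also leave open how a carboxylic acid in place of the hydroxycarbamoyl end would read on the long chain.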